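The source may report more compounds than this note shows. Statements on the series, on what has been measured and on what is new or still open speak of the compounds shown alone.

The series shares one core, seen in compound 1 `Nc1scc(CN2CCN(c3cccc(F)c3)CC2)c1C(=O)c1ccc(Cl)cc1`. In an assay on CHO cells for displacement of a labelled ligand from adenosine receptor A1 (Homo sapiens), read by scintillation counting, with a stated time of 120 min, tested at 10 uM (a lower number here means less inhibition, a higher number more inhibition at the concentration tested (going by the name of the read-out)), compound 1 gives 1%. Compound 2 `Nc1scc(CN2CCN(c3ccccc3F)CC2)c1C(=O)c1ccc(Cl)cc1` carries 2-fluorophenyl on the amine nitrogen in the ring in place of 3-fluorophenyl, and in this assay compound 2 gives 4%, the step being a number 3 percentage points higher from compound 1 to compound 2 (within the scatter). Compound 3 `Nc1scc(CN2CCN(c3cc(F)ccc3F)CC2)c1C(=O)c1ccc(Cl)cc1` bears 2,5-difluorophenyl at that nitrogen, and in this assay compound 3 gives 1%. Compound 3 stands level with compound 1, the two together the lowest of the three numbers, with the step of no change at the digits printed from compound 1 to compound 3 (within the scatter); from compound 2 the step is a number 3 percentage points lower from compound 2 to compound 3 (within the scatter).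

Compound 4 `Nc1scc(CN2CCN(c3cccc(Cl)c3)CC2)c1C(=O)c1ccc(Cl)cc1` is the next case: 3-chlorophenyl in place of 2,5-difluorophenyl on an amine nitrogen in a ring. For the measured compounds named here, every measured step so far has altered the phenyl on that amine nitrogen, and none moved the read-out beyond the scatter, as a number 3 percentage points lower from compound 2 to compound 3 (within the scatter) shows. Nothing measured speaks to 3-chlorophenyl in particular, so compound 4 is expected to stay in the same low region, and the expected step of a number 1 percentage points higher from compound 3 to compound 4 (within the scatter) is judged to lie within the scatter. Compound 4 is estimated at 2%, in a range from -8% to 12%.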

Compound 4, a percentage reported as inhibition, at one concentration (the size of the read-out at that concentration, not a potency): 0%
Estimate against measurement, compound 4: 2 percentage points above; the measured number falls inside the stated range.
By their numbers in this assay, from the lowest: compounds 4, 1, 3 and 2 (each within the scatter of the next).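

For the compounds shown here, until now the phenyl on the amine nitrogen had carried only fluoro, and compound 4 brings chloro to that phenyl for the first time. Going from 3-fluorophenyl to 3-chlorophenyl gives a number 1 percentage points lower from compound 1 to compound 4 (within the scatter) in this assay and so does not separate the two halogens at this position, at least for this pair. The comparisons with the other two fluorinated phenyls read the same, with a number 1 percentage points lower from compound 3 to compound 4 (within the scatter) and a number 4 percentage points lower from compound 2 to compound 4 (within the scatter) in this assay so that all four compounds remain within the scatter of one another, and nothing available bears on why the read-out stays so flat at this position.

The compounds shown carry only fluoro or chloro on that phenyl, so it remains open whether a methoxy group, a nitrile or a carboxylic acid there would give a clearly different number in this assay at the single concentration tested. On these data alone, the shared core also stays the same throughout, so it is equally open whether replacing the free amine on it with an amide, or the chloro on its other phenyl with a methoxy group, would change the read-out.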